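A few compounds are considered here, and "the series" means these few. Any claim that something is new, unique, unknown or untested is made for them only; others in the source may bear on it.

Measured in a functional assay on DU-145 cells (Homo sapiens) for inhibition, read by trypan blue exclusion, with a stated time of 96 h; on this read-out lower numbers stand for stronger inhibition of growth and higher numbers for weaker inhibition of growth:

Compound 1 `O=C(/C(=C\c1ccc(O)c([N+](=O)[O-])c1)SCc1ccc(Br)cc1)c1ccc(Br)cc1`: 10000 nM
Compound 2 `O=C(/C(=C\c1ccc(O)c([N+](=O)[O-])c1)SCc1ccc(Br)cc1)c1ccc(Cl)cc1Cl`: 10000 nM
Compound 3 `O=C(/C(=C\c1ccc(O)c([N+](=O)[O-])c1)SCc1ccc(Br)cc1)c1ccc(O)cc1O`: > 100000 nM (a limit)

Compound 3 is reported only as a limit, > 100000 nM. It therefore stands at the weak end of the three, and its true value is not known. Compound 4 `N#Cc1ccc(C(=O)/C(=C\c2ccc(O)c([N+](=O)[O-])c2)SCc2ccc(Br)cc2)cc1` has not yet been measured in this assay. It carries 4-cyanophenyl in place of 2,4-dihydroxyphenyl on a carbonyl carbon.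

For the measured compounds named here, three measured steps bear on this change. Two of them bring in the group that compound 4 gives up: an at least 10-fold higher number from compound 1 to compound 3 (1.00 log units; beyond the scatter) and an at least 10-fold higher number from compound 2 to compound 3 (1.00 log units; beyond the scatter). The third exchanges one halogenated group for another: no change at the digits printed from compound 1 to compound 2 (within the scatter). Compound 4 replaces the 2,4-dihydroxyphenyl with a group that has not been tested here, so the comparison with compound 1 and compound 2 is only indirect. Reversing the two large steps still points to a clearly lower number, with compound 4 expected to fall near compound 1 at 10000 nM.

The expected change is an at least 10-fold lower number from compound 3 to compound 4 (1.00 log units; beyond the scatter), towards stronger inhibition of growth. For compound 4 the estimated value is 10000 nM, with an expected range from 3000 nM to 40000 nM.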

Compound 4, concentration for 50% growth inhibition: 10000 nM
Beside the measured number, compound 4's estimate shows no gap at the digits printed, within the range that was stated.
By their numbers in this assay, from the lowest: compounds 1, 2 and 4 (each within the scatter of the next). At a limit, above all of these: compound 3.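

In this assay, the carbonyl carbon now carries a group with no halogen, and 4-cyanophenyl sits level with both halogenated groups: no change at the digits printed from compound 1 to compound 4 (within the scatter), and no change at the digits printed from compound 2 to compound 4 (within the scatter). A halogen on this ring is therefore not required for the level shared by these three compounds, and the step back from the dihydroxy group, an at least 10-fold lower number from compound 3 to compound 4 (1.00 log units; beyond the scatter), gives 2,4-dihydroxyphenyl a second and third comparison in which it alone stands apart. Compound 3 remains a limit, so this step gives a bound and not a size: the limit of > 100000 nM in this assay, at which 1 of the 4 values shown sits.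

Among the compounds shown, 2,4-dihydroxyphenyl is the only group with hydrogen-bond donors, so they cannot tell whether one hydroxy group alone would have the same effect, or whether a methoxy group, an amine or a carboxylic acid on this ring would stay with compound 1, compound 2 and compound 4 or fall with compound 3. They also leave open whether any group at this place can give clearly stronger inhibition of growth than compound 4, which gives 10000 nM.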